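Vinyl in place of propyl: an expected half-life

The compounds below may be only part of what the source reports. "The series", "measured", "known", "first", "only" and "open" are said of these compounds alone.

Measured in a physicochemical assay for pharmacokinetics, read by LC-MS, in phosphate buffer, tested at 1 uM; on this read-out lower numbers stand for a shorter-lived compound and higher numbers for a longer-lived compound:
Compound 1 `C#CCNC(=O)c1cccc2c1cc(C)n2-c1nc2c(c(NCc3ccccc3)n1)CCCC2`: > 24 h (a limit, not a number)
Compound 2 `CCCC#CC(=O)Nc1cccc2c1cc(C)n2-c1nc2c(c(NCc3ccccc3)n1)CCCC2`: 21.6 h

In this assay, among the measured compounds shown here, compound 2 gives 21.6 h as the only actual number so far. Compound 1 gives > 24 h and that is a limit of the assay. Compound 3 `C=CC#CC(=O)Nc1cccc2c1cc(C)n2-c1nc2c(c(NCc3ccccc3)n1)CCCC2` differs from compound 2 by vinyl in place of propyl on a triple-bonded carbon with vinyl in place of propyl on a triple-bonded carbon. For the measured compounds named here, no measured step makes this change. Going by the values given here, the one measured step of an at least 1.1-fold lower number from compound 1 to compound 2 (0.04 log units; that floor lies within the scatter) is a different change and rests on the limit of > 24 h in this assay, at which 1 of the 2 values shown sits, as its upper end. On that slender basis the expected 1.1-fold lower number from compound 2 to compound 3 (0.03 log units; within the scatter) is no step beyond the scatter, in neither direction. Compound 3 is estimated at 20 h with an expected range of 10 h to 30 h in this assay here.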

Compound 3, half-life: 5.08 h
For compound 3 the middle estimate is 3.9-fold (0.60 log units) above the measured one; the measured number lies below the stated range.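

In this assay vinyl in place of propyl on a triple-bonded carbon gives a 4.3-fold lower number from compound 2 to compound 3 (0.63 log units; beyond the scatter) and so shows that this position can move the half-life beyond the scatter. The comparison with compound 1 shows an at least 4.7-fold lower number from compound 1 to compound 3 (0.67 log units; beyond the scatter) and is only a floor, for the value of compound 1 is a limit: the limit of > 24 h in this assay, at which 1 of the 3 values shown sits. The compounds shown leave open whether the shorter chain or the double bond goes with the shorter half-life. An ethyl group on the same triple-bonded carbon would separate the two.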